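The source may report more compounds than this note shows. Statements on the series, on what has been measured and on what is new or still open speak of the compounds shown alone.

Compound 1 `CS(=O)(=O)c1cnc(O[C@H]2CC[C@H](OC3CCN(C(=O)OC4CCOC4)CC3)CC2)cn1` — 109%
Compound 2 `CS(=O)(=O)c1cnc(O[C@H]2CC[C@H](OC3CCN(C(=O)C4(C(F)(F)F)CC4)CC3)CC2)cn1` — 140%

Among the compounds with values here, in a functional assay on isolated protein for agonist activity at Glucose-dependent insulinotropic receptor (Rattus norvegicus), read by HTRF and cAMP accumulation (on this read-out lower numbers stand for smaller maximal responses and higher numbers for larger maximal responses), compound 2 gives 140%, the higher of the two numbers measured so far; its nearest neighbour is compound 1, which in this assay gives 109%, and the step is a number 31 percentage points higher from compound 1 to compound 2 (beyond the scatter). Compound 3 `CS(=O)(=O)c1cnc(O[C@H]2CC[C@H](OC3CCN(CC4(C(F)(F)F)CCCC4)CC3)CC2)cn1` has not yet been measured. Compared with compound 2 it carries a group of 10 heavy atoms (7 carbon, 3 fluorine; one five-membered non-aromatic ring of carbon only) in place of a group of 9 heavy atoms (5 carbon, 1 oxygen, 3 fluorine; one three-membered non-aromatic ring of carbon only), on an amine nitrogen in a ring.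

Within the data shown here, only one measured step bears on this change. The step of a number 31 percentage points higher from compound 1 to compound 2 (beyond the scatter) exchanged a group on a carbonyl carbon at this same amine nitrogen and was large. The change from compound 2 to compound 3 is of a different kind: the carbonyl leaves together with the three-membered ring, and a group with no hydrogen-bond acceptor enters, so the measured step gives only a hint that this part of the molecule can move the maximal response by a large amount, without fixing a direction. Compound 3 is therefore expected to show a moderate step of a number 20 percentage points lower from compound 2 to compound 3 (beyond the scatter), with wide uncertainty. The estimate for compound 3 is 120%, in a range from 90% to 150%.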

Compound 3, largest response reached (Emax), in percent of the reference or control that the assay uses: 88%
Compound 3: the middle estimate sits 32 percentage points above what was measured; the measured number lies below the stated range.
By their numbers in this assay, from the lowest: compound 3; then compound 1; then compound 2.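

In this assay, the step of a number 52 percentage points lower from compound 2 to compound 3 (beyond the scatter) shows that the group on the amine nitrogen in the ring can lower the maximal response as well as raise it, and that the lowering can be large. The second comparison, a number 21 percentage points lower from compound 1 to compound 3 (beyond the scatter), is smaller but also beyond the scatter, so among these three compounds the one without a carbonyl on this nitrogen gives the lowest number, and both carbonyl-bearing compounds stand above it. No measurement is available that accounts for this fall.

The change from compound 2 to compound 3 removes the carbonyl and replaces the three-membered carbon ring with a five-membered one in a single step, so the compounds shown cannot say how much of the fall goes with each of these two differences. On these data alone, a 1-(trifluoromethyl)cyclopentyl group on a carbonyl, or a 1-(trifluoromethyl)cyclopropylmethyl group directly on the amine nitrogen, would separate the two, and how a urea or a sulfonamide at this nitrogen would compare also remains open.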